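Lengthening the Side Chain of Compound 1: Tolerability Outlook

The compounds below may be only part of what the source reports. "The series", "measured", "known", "first", "only" and "open" are said of these compounds alone.

Compound 1 `CC/C(Nc1ccc(CN2CCCCC2)cc1)=C1/C(=O)Nc2ccc(NS(=O)(=O)CC)cc21` was examined in an ADME assay on HepG2 cells (Homo sapiens) for cytotoxicity, read by MTT assay, with a stated time of 48 h; a lower number here means that less compound is tolerated, a higher number that more compound is tolerated. In this assay compound 1 gives > 6 uM, which is a limit of the assay rather than a measured number. Two further compounds share the same core. Compound 2 `CCS(=O)(=O)Nc1ccc2c(c1)/C(=C/Nc1ccc(CN3CCCCC3)cc1)C(=O)N2` gives 5 uM in this assay. Compound 3 `CC(=O)Nc1ccc2c(c1)/C(=C(/Nc1ccc(CN3CCCCC3)cc1)c1ccccc1)C(=O)N2` gives > 6 uM, again a limit and not a number. Compound 1 therefore stands at the limit of > 6 uM in this assay, at which 2 of the 3 values shown sit. Within the data shown here, the single numerical value in the set, that of compound 2, does not allow any ordering of the three compounds, since limits and a nearby number cannot be ranked against each other.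

Compound 4 `CCCC/C(Nc1ccc(CN2CCCCC2)cc1)=C1/C(=O)Nc2ccc(NS(=O)(=O)CC)cc21` has not yet been measured. It differs from compound 1 in one place: ethyl in place of hydrogen on a saturated chain carbon, two bonds along the chain from a double-bonded chain carbon. Among the measured compounds shown here, no measured pair in this set shows what such a change does to tolerability, so the step can only be expected, not read off. The step expected here, a step that the limit leaves unreadable from compound 1 to compound 4, is none beyond the usual scatter. For compound 4 the expected value is 7 uM, with a range from 3 uM to 15 uM, and it seems likely that this assay will once more report only a limit.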

Compound 4, half-maximal toxic concentration: > 6 uM
Compound 4: no number, only a limit; the forecaster's own chance of this, stated with the estimate: 65%; the middle value lies beyond the limit too.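

Compound 4 gives > 6 uM in this assay, which is a limit of the assay and not a number. Compound 1 also stands at a limit, so no step can be read between compound 1 and compound 4: the limit of > 6 uM in this assay, at which 3 of the 4 values shown sit.

The compounds shown leave open whether ethyl in place of hydrogen on a saturated chain carbon changes how much compound is tolerated.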